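Removing One Ring Chlorine: Expected Cytotoxicity of Compound 4

A few compounds are considered here, and "the series" means these few. Any claim that something is new, unique, unknown or untested is made for them only; others in the source may bear on it.

Compound 1 `Clc1ccc(C2ON=C(c3ccccc3Cl)O2)cc1Cl`: in an ADME assay on HEK293 cells (Homo sapiens) for cytotoxicity, read by MTT assay, with a stated time of 44 h (a lower number here means a stronger inhibitor, a higher number a weaker inhibitor), compound 1 gives > 100000 nM, a limit of the assay.
Compound 2 `Clc1ccc(C2ON=C(c3ccccc3Cl)O2)cc1`: in this assay compound 2 gives > 100000 nM, a limit of the assay.
Compound 3 `CC1(c2cccc(Br)c2)ON=C(c2ccccc2Cl)O1`: in this assay compound 3 gives > 100000 nM, a limit of the assay.

Compound 1 stands at the limit of > 100000 nM in this assay, at which 3 of the 3 values shown sit, so its place among the measured compounds is known only as a limit. Compound 4 `Clc1cccc(C2ON=C(c3ccccc3Cl)O2)c1` differs from compound 1 by hydrogen in place of chloro on an aromatic carbon. For the measured compounds named here, the one measured step of this kind, a step that the two limits leave unreadable from compound 1 to compound 2, also takes a chloro group off an aromatic carbon, yet its size stays unreadable because both ends sit at the limit of > 100000 nM in this assay, at which 3 of the 3 values shown sit. Going by the values given here, no measured step in this assay gives a readable size, so for the change to compound 4 no shift beyond the scatter is expected, and the result will most likely again be a limit. Compound 4 is therefore expected to give 100000 nM, between 30000 nM and 300000 nM, an expected step of a number no higher from compound 1 to compound 4 (the limit leaves the size open).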

Compound 4, half-maximal inhibitory concentration: > 100000 nM
Compound 4: a limit, no number; the forecaster's own chance of this, stated with the estimate: 85%; the middle value sits exactly at the limit.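

No step can be read from compound 1 to compound 4, because both sit at a limit of the assay: the limit of > 100000 nM in this assay, at which 4 of the 4 values shown sit.

The compounds shown leave open whether hydrogen in place of chloro changes the result at all in this assay.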